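Aryl variation at the aminothienopyrimidine: toward phenyl

The compounds below may be only part of what the source reports. "The series", "measured", "known", "first", "only" and "open" are said of these compounds alone.

Measured so far:
compound 1 `CC(C)c1ccc(-c2nc(N)c3cc(Cc4ccccc4)sc3n2)o1` — 283 nM
compound 2 `Nc1nc(-c2ncco2)nc2sc(Cc3ccccc3)cc12` — 310 nM
compound 3 `Cn1cnc(-c2nc(N)c3cc(Cc4ccccc4)sc3n2)c1` — 2330 nM

In a functional assay on CHO-K1 cells for antagonist activity at adenosine receptor A1 (Homo sapiens), read by a beta-galactosidase reporter and cAMP accumulation, with stated times of 15 min and 6 h (on this read-out higher numbers stand for weaker inhibition and lower numbers for stronger inhibition), compound 1 and compound 2 give numbers within the scatter of one another, a 1.1-fold higher number from compound 1 to compound 2 (0.04 log units; within the scatter). Compound 3 stands highest of the three: an 8.2-fold higher number from compound 1 to compound 3 (0.92 log units; beyond the scatter) and a 7.5-fold higher number from compound 2 to compound 3 (0.88 log units; beyond the scatter). Its nearest neighbour is compound 2, its furthest compound 1, both beyond the scatter.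

Compound 4 `Nc1nc(-c2ccccc2)nc2sc(Cc3ccccc3)cc12` is not yet measured. It differs from compound 3 in one place: phenyl in place of 1-methyl-1H-imidazol-4-yl on an aromatic carbon. Among the compounds with values here, no measured step involves a phenyl group, so none bears directly on this change. What the series does show is that the 1-methyl-1H-imidazol-4-yl of compound 3 gives the weakest inhibition, while the two other five-membered aromatics in compound 1 and compound 2 sit close together and well below it. Leaving the methylimidazolyl is therefore expected to bring the number down toward that of compound 1 and compound 2, with the estimated step of a 5.8-fold lower number from compound 3 to compound 4 (0.77 log units; beyond the scatter) in this assay. Within the data shown here, for compound 4 the estimate is 400 nM, within 120 nM to 1500 nM, the wide range reflecting that no phenyl analogue has been measured.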

Compound 4, inhibition constant: 151 nM
Estimate against measurement, compound 4: 2.6-fold (0.42 log units) above, and the stated range covers the measured number.
By their numbers in this assay, from the lowest: compounds 4, 1 and 2 (each within the scatter of the next, the first and the last beyond it); then compound 3.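

Within the data shown here, at the aromatic carbon between two ring nitrogen atoms, phenyl, a six-membered aromatic ring of carbon only, is tolerated in this assay: a 15-fold lower number from compound 3 to compound 4 (1.19 log units; beyond the scatter) is the largest step so far, a 2.1-fold lower number from compound 2 to compound 4 (0.31 log units; beyond the scatter) lies just beyond the scatter, and a 1.9-fold lower number from compound 1 to compound 4 (0.27 log units; within the scatter) stays within it. Every earlier group at this position carried hetero atoms in its ring, so compound 4 shows that such atoms are not needed for numbers at this level. Nothing available explains the gap between phenyl and 1-methyl-1H-imidazol-4-yl.

Open, on these data alone, is whether a methoxy group or a chlorine on the phenyl, or a pyridyl in its place, would hold or move the number. Also open, as far as these compounds go, is how an imidazolyl without the methyl would compare with 1-methyl-1H-imidazol-4-yl.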